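Working notes: from compound 3 to compound 4

The source may report more compounds than this note shows. Statements on the series, on what has been measured and on what is new or still open speak of the compounds shown alone.

Measured so far:
compound 1 `O=C(N/N=C/c1ccccc1)c1cccnc1Nc1cccc(C(F)(F)F)c1` — 31%
compound 2 `O=C(N/N=C/c1cccc(F)c1)c1cccnc1Nc1cccc(C(F)(F)F)c1` — 29.8%
compound 3 `O=C(N/N=C/c1cccc(O)c1)c1cccnc1Nc1cccc(C(F)(F)F)c1` — 35.8%

All three were read in a functional assay on the whole organism (strain Wistar) for inhibition, with Rattus norvegicus as the target, read by paw edema, with a stated time of 4 h, at a dose of 10 mg/kg by the intraperitoneal route; on this read-out lower numbers stand for less inhibition and higher numbers for more inhibition at the one dose given (going by the name of the read-out). Compound 3 gives the highest of the three numbers, but the step of a number 4.8 percentage points higher from compound 1 to compound 3 (within the scatter) and the step of a number 6 percentage points higher from compound 2 to compound 3 (within the scatter) are both within the scatter, so no order among compounds 1, 2 and 3 can be claimed; likewise a number 1.2 percentage points lower from compound 1 to compound 2 (within the scatter) is within the scatter.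

Compound 4 `COc1ccc(/C=N/NC(=O)c2cccnc2Nc2cccc(C(F)(F)F)c2)cc1OC` has not yet been measured. It differs from compound 3 as follows: 3,4-dimethoxyphenyl in place of 3-hydroxyphenyl on a carbon with a double bond to nitrogen. For the measured compounds named here, the steps that bear on this change are the two that alter the same phenyl ring, a number 4.8 percentage points higher from compound 1 to compound 3 (within the scatter) and a number 6 percentage points higher from compound 2 to compound 3 (within the scatter), together with a number 1.2 percentage points lower from compound 1 to compound 2 (within the scatter); every one of them is within the scatter. Going by the values given here, no measured step involves a methoxy group, so the effect of the 3,4-dimethoxyphenyl is not covered by the series. Since no substituent change on that ring has moved the read-out beyond the scatter, the expected step is a number 3.8 percentage points lower from compound 3 to compound 4 (within the scatter), with no direction beyond the scatter.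

Compound 4 is therefore expected to give 32%, estimated to lie between 22% and 42%.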

Compound 4, a percentage reported as inhibition, in the whole organism at one dose (the size of the read-out at that dose, not a potency): 52.9%
For compound 4 the middle estimate is 20.9 percentage points below the measured one; the whole stated range lies below it.
By their numbers in this assay, from the lowest: compounds 2, 1 and 3 (each within the scatter of the next); then compound 4.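

In this assay, for the compounds shown here, 3,4-dimethoxyphenyl is the only group on the carbon with a double bond to nitrogen that moves the read-out beyond the scatter: the series shows a number 17.1 percentage points higher from compound 3 to compound 4 (beyond the scatter) against 3-hydroxyphenyl, a number 23.1 percentage points higher from compound 2 to compound 4 (beyond the scatter) against 3-fluorophenyl and a number 21.9 percentage points higher from compound 1 to compound 4 (beyond the scatter) against phenyl. This place therefore does respond to a change of its aryl group, which the three earlier compounds, all within the scatter of one another, could not show. No measured evidence accounts for the step.

From the compounds shown here alone, whether one methoxy group alone would give a step of this size remains open, since the two methoxy groups appear only together. Also open, going by these compounds, is how an amine or a carboxylic acid on this phenyl ring would read at this dose.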